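Aryl Swap on the Triazole Nitrogen: Forecast for Compound 4

A few compounds are considered here, and "the series" means these few. Any claim that something is new, unique, unknown or untested is made for them only; others in the source may bear on it.

Measured so far in a functional assay on MCF7 cells (Homo sapiens) for antiproliferative activity, read by MTT assay, with a stated time of 48 h; on this read-out higher numbers stand for weaker inhibition and lower numbers for stronger inhibition:
compound 1 `N#CC1=C(N)Oc2c(N)cc3nc4ccccc4nc3c2C12C(=O)N(Cc1cnnn1-c1ccccc1Br)c1ccccc12`: 30700 nM
compound 2 `N#CC1=C(N)Oc2c(N)cc3nc4ccccc4nc3c2C12C(=O)N(Cc1cnnn1-c1cccc(C(F)(F)F)c1)c1ccccc12`: 31600 nM
compound 3 `N#CC1=C(N)Oc2c(N)cc3nc4ccccc4nc3c2C12C(=O)N(Cc1cnnn1-c1ccc(F)c(Cl)c1)c1ccccc12`: 17800 nM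

All three compounds share one core and differ only in the aryl group on the aromatic nitrogen of the triazole. For the measured compounds named here, on the numbers so far, compound 3 sits together with compounds 1 and 2: the steps of a 1.7-fold lower number from compound 1 to compound 3 (0.24 log units; within the scatter) and a 1.8-fold lower number from compound 2 to compound 3 (0.25 log units; within the scatter) both fall within the scatter, and the step of a 1.0-fold higher number from compound 1 to compound 2 (0.01 log units; within the scatter) is likewise within it. No aryl change measured here has moved this assay beyond repeat-to-repeat noise.

Compound 4 `Cc1cc(C)c(-n2nncc2CN2C(=O)C3(C(C#N)=C(N)Oc4c(N)cc5nc6ccccc6nc5c43)c3ccccc32)c(C)c1` is the next point. The change is 2,4,6-trimethylphenyl in place of 3-chloro-4-fluorophenyl on an aromatic nitrogen. All three measured steps bear on it, since each replaces one aryl group on that nitrogen with another, and each stayed within the scatter. The data therefore give no reason to expect a step in this assay of any size beyond the scatter, in either direction.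

Compound 4 is accordingly estimated at 22000 nM, with a range from 9000 nM to 55000 nM. That estimate implies an expected step of a 1.2-fold higher number from compound 3 to compound 4 (0.09 log units; within the scatter), which is expected to remain within the scatter.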

Compound 4, half-maximal inhibitory concentration: > 50000 nM
Compound 4: no number, only a limit; the forecaster's own chance of this, stated with the estimate: 10%; at least 2.2-fold (0.35 log units) between middle value and limit.
By their numbers in this assay, from the lowest: compounds 3, 1 and 2 (each within the scatter of the next). At a limit, above all of these: compound 4.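

In this assay compound 4 gives no number, only a limit of the assay: the limit of > 50000 nM in this assay, at which 1 of the 4 values shown sits. That limit still yields a readable result, an at least 2.8-fold higher number from compound 3 to compound 4 (0.44 log units; beyond the scatter), the only step on the aromatic nitrogen of the triazole shown here that is printed as beyond the scatter, so this position does not accept every aryl group alike, as the earlier compounds alone might have suggested. The two other steps, an at least 1.5-fold higher number from compound 2 to compound 4 (0.19 log units; that floor lies within the scatter) and an at least 1.6-fold higher number from compound 1 to compound 4 (0.21 log units; that floor lies within the scatter), have floors within the scatter, so on their own they do not separate compound 4 from compound 2 or compound 1, although the real gaps could be wider.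

The 2,4,6-trimethylphenyl group of compound 4 is the only aryl group here with no halogen, and the compounds shown cannot tell whether the change in this read-out follows from the methyl groups, their number or their placement, or from the loss of halogen. They also leave open how a plain phenyl group, or an aryl group carrying a methoxy group or an amine, would behave at this position.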